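Paw edema series: chloromethyl to (dimethylamino)methyl

A few compounds are considered here, and "the series" means these few. Any claim that something is new, unique, unknown or untested is made for them only; others in the source may bear on it.

Measured so far in a functional assay on the whole organism (strain Wistar albino) for inhibition, with Rattus norvegicus as the target, read by paw edema, with stated times of 30 min and 2 h, at a dose of 20 mg/kg by the oral route; a higher number here means more inhibition at the dose given (going by the name of the read-out), a lower number less inhibition:
compound 1 `CN(C)Cc1ccc2oc(-c3ccccc3Cl)cc(=O)c2c1` — 36.2%
compound 2 `COc1ccc(-c2cc(=O)c3cc(CCl)ccc3o2)cc1` — 32.2%

In this assay compound 2 stands at the low end of the two numbers, but its distance from compound 1 lies within the scatter, so the two numbers count as level. For the measured compounds named here, no pair among the measured compounds differs in only one place, so no single-change step is available.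

Compound 3 `COc1ccc(-c2cc(=O)c3cc(CN(C)C)ccc3o2)cc1` is the next compound to go into this assay. It differs from compound 2 by dimethylamino in place of chloro on a saturated chain carbon bound to an aromatic carbon. Compound 1 also carries a (dimethylamino)methyl group, yet it differs from compound 3 elsewhere too; the value of compound 1, 36.2%, is therefore only a rough pointer. With both measured values within the scatter of each other, the expected step from compound 2 to compound 3 a number 1.8 percentage points higher from compound 2 to compound 3 (within the scatter) is none beyond the scatter. Compound 3 is estimated at 34%, ranging from 22% to 46%.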

Compound 3, a percentage reported as inhibition, in the whole organism at one dose (the size of the read-out at that dose, not a potency): 36%
Compound 3: the middle estimate sits 2 percentage points below what was measured; the range from low to high includes it.
By their numbers in this assay, from the lowest: compounds 2, 3 and 1 (each within the scatter of the next).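

Dimethylamino in place of chloro on a saturated chain carbon bound to an aromatic carbon gives, in this assay, a number 3.8 percentage points higher from compound 2 to compound 3 (within the scatter). This first single-change step in the series therefore separates the two groups by nothing beyond the scatter, so at this place the read-out does not tell chloro from dimethylamino at the one dose tested. No measurement at hand bears on the reason for this result.

The compounds shown leave open whether another group on this chain carbon, such as a morpholine, a carboxylic acid or a longer amine chain, would give a step beyond the scatter. They also leave open whether chloro and dimethylamino would still read alike at other doses, since a single-dose percentage is not a potency.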